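Hydroxy to methoxy, tried on a second core

The source may report more compounds than this note shows. Statements on the series, on what has been measured and on what is new or still open speak of the compounds shown alone.

Measured compounds:
- compound 1, `Cc1ccccc1/C(CCN1CCN(c2ccccn2)CC1)=N\O`: 72%
- compound 2, `CO/N=C(/CCN1CCN(c2ccccn2)CC1)c1ccccc1C`: 72%
- compound 3, `O/N=C(\CCCN1CCN(c2ccccn2)CC1)c1ccc(F)cc1`: 62%

All three were tested in a functional assay on HEK293 cells with D(4) dopamine receptor (Homo sapiens) as the target, read by FLIPR; on this read-out lower numbers stand for smaller maximal responses and higher numbers for larger maximal responses. Compound 1 and compound 2 share a core and differ only by methyl in place of hydrogen on an oxygen. That change left the read-out unchanged: no change at the digits printed from compound 1 to compound 2 (within the scatter). Compound 3 has a different core; the difference between the two cores is not broken down here. In this assay compound 3 gives 62%, and its gap to compound 1 and to compound 2 lies within the usual scatter, so no order among the three can be read from these numbers.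

Compound 4, `CO/N=C(\CCCN1CCN(c2ccccn2)CC1)c1ccc(F)cc1`, has not yet been measured in this assay. It is related to compound 3 by methyl in place of hydrogen on an oxygen, the same change that turns compound 1 into compound 2, made at the same place, on an oxygen whose other neighbour is a double-bonded nitrogen. Going by the values given here, the only guide to its effect is the single earlier pair, where it made no change at the digits printed from compound 1 to compound 2 (within the scatter). On that basis the step from compound 3 to compound 4 is expected to be small as well, no change at the digits printed from compound 3 to compound 4 (within the scatter), because the earlier step of no change at the digits printed from compound 1 to compound 2 (within the scatter) stayed within the scatter. Whether the change behaves the same on the core of compound 3 is not known from any other pair here, so the expectation carries a wide margin. Compound 4 is therefore estimated to give 62% in this assay, with a range from 48% to 76%.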

Compound 4, largest response reached (reported as efficacy), in percent of the reference or control that the assay uses: 60%
The estimate for compound 4 lay 2 percentage points above the measured number; measured number inside the range.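

Methyl in place of hydrogen on the oxygen, the step from hydroxy to methoxy, gives a number 2 percentage points lower from compound 3 to compound 4 (within the scatter) in this assay, so on this second core too the change leaves the maximal response where it was. Setting this step beside the earlier one shows that the change carries over between the two cores without a visible difference: the same change on two cores in this assay, no change at the digits printed (within the scatter) from compound 1 to compound 2 and a number 2 percentage points lower (within the scatter) from compound 3 to compound 4, 2 percentage points apart, within the scatter of two such steps. Going by these compounds alone, this is agreement between only two pairs in a single read-out, so it shows that the swap made little difference to the largest response on these two cores, but it does not show that the same would hold on any other core, and it gives no reason for the lack of effect.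

The compounds shown carry only hydrogen or methyl on this oxygen, so it remains open whether a larger group there, such as ethyl or benzyl, would leave the response just as flat. Going by these compounds, it also remains open whether replacing the whole hydroxy group with an amine, or the oxygen-bearing nitrogen unit with a carbonyl, would keep the response in the same range.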